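The source may report more compounds than this note shows. Statements on the series, on what has been measured and on what is new or still open speak of the compounds shown alone.

In a functional assay on HepG2 cells (Homo sapiens) for antiproliferative activity, read by MTT assay, with a stated time of 48 h (on this read-out lower numbers stand for stronger inhibition and higher numbers for weaker inhibition), compound 1 `N#CC1=C(N)Oc2c(c3nc4ccccc4nc3c3ccccc23)C12C(=O)N(Cc1cnnn1-c1ccc([N+](=O)[O-])cc1)c1ccccc12` gives > 50000 nM, which is a limit of the assay and not a number. Compound 2 `N#CC1=C(N)Oc2c(c3nc4ccccc4nc3c3ccccc23)C12C(=O)N(Cc1cnnn1-c1cc(Cl)ccc1Cl)c1ccccc12` in this assay gives > 50000 nM, again only a limit. The step that the two limits leave unreadable from compound 1 to compound 2 thus cannot be sized, since both of its values sit at the limit. Compound 3 `N#CC1=C(N)Oc2c(N)cc3nc4ccccc4nc3c2C12C(=O)N(Cc1cnnn1-c1ccc(F)cc1)c1ccccc12` is measured in this assay at > 50000 nM, once more a limit rather than a number. On the numbers shown, compound 3 therefore stands where every measured compound stands, at the limit of > 50000 nM in this assay, at which 3 of the 3 values shown sit. Compound 4 `N#CC1=C(N)Oc2c(N)cc3nc4ccccc4nc3c2C12C(=O)N(Cc1cnnn1-c1cc(Cl)ccc1Cl)c1ccccc12` differs from compound 3 by 2,5-dichlorophenyl in place of 4-fluorophenyl on an aromatic nitrogen. For the measured compounds named here, the only measured step that bears on this change is a step that the two limits leave unreadable from compound 1 to compound 2, and its size is not readable. With nothing to suggest a shift beyond the scatter, compound 4 is expected to stay close to compound 3, with an estimated step that the limit leaves unreadable from compound 3 to compound 4. Compound 4 is accordingly estimated at 80000 nM, within a range from 30000 nM to 300000 nM, and most likely the assay will again report only a limit.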

Compound 4, half-maximal inhibitory concentration: 33100 nM
Beside the measured number, compound 4's estimate is 2.4-fold (0.38 log units) above it; measured number inside the range.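

For the compounds shown here, with 2,5-dichlorophenyl in place of 4-fluorophenyl on the aromatic nitrogen of the five-membered ring, the shared core gives the one step at this position that can be read at all, an at least 1.5-fold lower number from compound 3 to compound 4 (0.17 log units; that floor lies within the scatter). The true size of this step remains unknown, and the change is not shown to go beyond the usual scatter. Even so, compound 4 is the only compound shown that gives a number rather than a limit in this assay: the limit of > 50000 nM in this assay, at which 3 of the 4 values shown sit.

The step from compound 1 to compound 2 cannot be read, so the compounds shown do not tell whether 2,5-dichlorophenyl would have the same effect on the core of compound 1. From the compounds shown here alone, it also remains open how a 4-methoxyphenyl or a benzyl group on the same nitrogen would compare with compound 4.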